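A Sulfamoyl Group Replaces Hydrogen on a Phenyl Ring

The source may hold more compounds than are shown below. What is called first, only, known or untested is meant among the compounds shown, and "the series" means these compounds.

Measured compounds:
compound 1, `COc1ccc(C(c2ccccc2)c2nc(-c3ccc(Cl)cc3)c(CC(=O)O)s2)cc1`, giving 8.4 nM in an in vitro assay on HEK385-7 cells for displacement of a labelled ligand from prostaglandin D2 receptor 2 (Homo sapiens); on this read-out higher numbers stand for weaker inhibition and lower numbers for stronger inhibition
compound 2, `O=C(O)Cc1sc(C(c2ccc(F)cc2)c2ccc(F)cc2)nc1-c1ccccc1`, giving 16 nM in this assay

Of the two numbers in hand, compound 2 carries the higher one, but its gap to compound 1 stays within the scatter of repeated runs, so the two compounds cannot be placed in any order on this read-out.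

The next compound, compound 3, is `NS(=O)(=O)c1ccc(-c2nc(C(c3ccc(F)cc3)c3ccc(F)cc3)sc2CC(=O)O)cc1`. It keeps the core of compound 2 and differs from it in one place: sulfamoyl in place of hydrogen on an aromatic carbon. The phenyl ring on the shared core thus becomes a 4-sulfamoylphenyl ring, on the aromatic carbon para to a large group.

Going by the values given here, no measured pair shows this change, so there is no step to lean on. The two numbers in hand, from compound 1 and compound 2, both lie close together despite a change on the same ring, and that gives some ground to expect compound 3 to stay near compound 2, with a step from compound 2 to compound 3 of a 1.3-fold higher number from compound 2 to compound 3 (0.10 log units; within the scatter) expected, no larger than the scatter in either direction. Compound 3 is accordingly estimated at 20 nM in this assay, within a range from 5 nM to 80 nM.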

Compound 3, half-maximal inhibitory concentration: 1500 nM
Compound 3: middle estimate off by 75-fold (1.88 log units), on the low side, and the stated range ends below it.
By their numbers in this assay, from the lowest: compounds 1 and 2 (each within the scatter of the next); then compound 3.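

Replacing hydrogen with sulfamoyl on the aromatic carbon para to a large group, which turns the phenyl ring into a 4-sulfamoylphenyl ring, produces a 94-fold higher number from compound 2 to compound 3 (1.97 log units; beyond the scatter) in this assay, a large step beyond the scatter. Going by these compounds alone, this is the first change at this position that can be read on its own, and it shows that the position does not accept every group: on an otherwise unchanged core, this one substitution is enough to separate compound 3 clearly from compound 2. Nothing in the data at hand bears on why the number rises so far with this change.

On these data alone, it remains open whether the rise belongs to sulfamoyl as a whole or to one of its parts, a question that a methylsulfonyl group, which has no nitrogen, or a smaller group such as an amine on the same carbon could help to settle. As far as these compounds go, it also remains open whether sulfamoyl would have a step of similar size on the core of compound 1, or on another carbon of the same ring.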